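A few compounds are considered here, and "the series" means these few. Any claim that something is new, unique, unknown or untested is made for them only; others in the source may bear on it.

Two compounds built on one shared core have so far been run through a functional assay on the whole organism (Hindlimb, strain albino) with Mus musculus as the target, in the maximal electroshock model, with a stated time of 0.5 h; a higher number here means that more compound is needed for the effect, a lower number that less compound is needed. Compound 1 `CC(=O)N1N=C(Nc2nc3ccc(C)cc3s2)CC1c1ccccc1` gives 106 umol/kg in this assay, the highest of the two numbers recorded. Its nearest neighbour, compound 2 `CC(=O)N1N=C(Nc2nc3ccc(C)cc3s2)CC1c1ccc(O)cc1`, gives 50.2 umol/kg in this assay, and the step of a 2.1-fold lower number from compound 1 to compound 2 (0.32 log units; beyond the scatter) came from a hydroxy in place of hydrogen on an aromatic carbon. Compound 3 `CC(=O)N1N=C(Nc2nc3ccc([N+](=O)[O-])cc3s2)CC1c1ccccc1` has not been measured; it differs from compound 1 in this way: nitro in place of methyl on an aromatic carbon. Among the measured compounds shown here, no measured step touches this part of the core or involves nitro or methyl, so the single known step shows only how far one small swap has moved the number, and that movement was modest. With nothing pointing in either direction, the step is expected to be a 1.1-fold lower number from compound 1 to compound 3 (0.03 log units; within the scatter), within the scatter. Compound 3 is therefore estimated to give 100 umol/kg in this assay, plausibly between 45 umol/kg and 220 umol/kg.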

Compound 3, dose for half-maximal effect: 216 umol/kg
For compound 3 the middle estimate is 2.2-fold (0.33 log units) below the measured one; the range from low to high includes it.
By their numbers in this assay, from the lowest: compound 2; then compound 1; then compound 3.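

In this assay, the move gives a 2.0-fold higher number from compound 1 to compound 3 (0.31 log units; beyond the scatter), which shows that this aromatic carbon on the fused part of the shared core also affects the dose needed. Among the compounds shown here, until now, the only measured change was elsewhere on the core, and it lowered the number, whereas nitro in place of methyl raises it, so more compound is needed for the effect. No measurement here explains why the number rose.

Going by these compounds, with only methyl and nitro compared at this position, it remains open whether the rise is specific to nitro or would follow other replacements for methyl, such as hydrogen, chlorine or an amine. It is also unknown whether the hydroxy change and the nitro change would act independently if combined in one compound.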